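Phenyl to Cyclopentyl: What to Expect of Compound 4

The compounds below may be only part of what the source reports. "The series", "measured", "known", "first", "only" and "open" are said of these compounds alone.

Three compounds share one core and differ only in the chain and amine that hang from an oxygen on an aromatic ring. Compound 1 `O=c1cc(-c2ccccc2)oc2ccc(OCCCN3CCC(O)CC3)cc12` gives 123 nM in an assay on isolated protein (Cavia porcellus) with Sigma non-opioid intracellular receptor 1 (Homo sapiens) as the target, read by radioligand binding; a higher number here means a weaker inhibitor, a lower number a stronger inhibitor. Compound 2 `O=c1cc(-c2ccccc2)oc2ccc(OCCCCCCN3CCC(O)CC3)cc12` gives 121 nM and compound 3 `CCN(CC)CCCCCCOc1ccc2oc(-c3ccccc3)cc(=O)c2c1` gives 100 nM. Compound 2 stands alongside the other two without any real separation: the step of a 1.0-fold lower number from compound 1 to compound 2 (0.01 log units; within the scatter), the step of a 1.2-fold lower number from compound 1 to compound 3 (0.09 log units; within the scatter) and the step of a 1.2-fold lower number from compound 2 to compound 3 (0.08 log units; within the scatter) all lie within the scatter, so the three numbers are indistinguishable.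

Compound 4 `O=c1cc(C2CCCC2)oc2ccc(OCCCCCCN3CCC(O)CC3)cc12` is made from compound 2 by a single change: cyclopentyl in place of phenyl on an aromatic carbon. Going by the values given here, none of the measured steps touches this group; each of them concerns the chain or the amine, and each stayed within the scatter. There is thus no direct guide for this change. A modest weakening is expected, a 1.8-fold higher number from compound 2 to compound 4 (0.26 log units; within the scatter), with wide uncertainty. Compound 4 is estimated at 220 nM, expected to fall between 60 nM and 800 nM.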

Compound 4, half-maximal inhibitory concentration: 55 nM
Compound 4: middle estimate off by 4.0-fold (0.60 log units), on the high side; measured number below the stated range.
By their numbers in this assay, from the lowest: compounds 4, 3, 2 and 1 (each within the scatter of the next, the first and the last beyond it).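

Going by these compounds alone, the group on the aromatic carbon next to the ring oxygen matters in this assay: cyclopentyl in place of phenyl gives a 2.2-fold lower number from compound 2 to compound 4 (0.34 log units; beyond the scatter), the only step in this set that lies beyond the scatter. The steps among compound 1, compound 2 and compound 3, which touch only the chain and the amine, all stayed within it. An aromatic ring is therefore not required at this position, since a five-membered non-aromatic ring of carbon gives the lower number here, though nothing given here accounts for that step.

From the compounds shown here alone, it remains open whether this result is particular to cyclopentyl or would also hold for cyclohexyl or an open-chain group such as isopropyl. Going by these compounds, it is also open whether the same exchange would give a similar step on compound 1 or compound 3, which carry a different chain or amine.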